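The source may hold more compounds than are shown below. What is called first, only, known or untested is meant among the compounds shown, and "the series" means these compounds.

Compound 2 `O=c1nc(N2CCN(NCCC3CCCCC3)CC2)sc2c([N+](=O)[O-])cc(C(F)(F)F)cc12` stands in an ADME assay on Vero cells (Chlorocebus sabaeus) for cytotoxicity, read by MTT assay, with a stated time of 72 h (a higher number here means that more compound is tolerated, a lower number that less compound is tolerated), at a limit of the assay rather than at a number, > 64 ug/mL. Compound 1 `O=c1nc(N2CCN(NC3CCCCC3)CC2)sc2c([N+](=O)[O-])cc(C(F)(F)F)cc12` also gives only a limit in this assay, > 64 ug/mL. Compound 3 `O=c1nc(N2CCN(NCc3ccc(Cl)cc3)CC2)sc2c([N+](=O)[O-])cc(C(F)(F)F)cc12` likewise stays at a limit in this assay, > 64 ug/mL. All three values sit at the limit of > 64 ug/mL in this assay, at which 3 of the 3 values shown sit, so the steps a step that the two limits leave unreadable from compound 1 to compound 2, a step that the two limits leave unreadable from compound 1 to compound 3 and a step that the two limits leave unreadable from compound 2 to compound 3 have no readable size. Compound 4 `O=c1nc(N2CCN(Nc3ccc(C(F)(F)F)cc3)CC2)sc2c([N+](=O)[O-])cc(C(F)(F)F)cc12` differs from compound 2 in one place: 4-(trifluoromethyl)phenyl in place of 2-cyclohexylethyl on an amine nitrogen. The measured steps bear on this change only in that cyclohexyl, 2-cyclohexylethyl and 4-chlorobenzyl on the amine nitrogen all left the compounds at the limit; none of them shows a size or a direction, so no movement beyond the scatter can be expected in this assay, and the most probable outcome is once more a limit. Compound 4 is therefore estimated to give 80 ug/mL, within a range from 40 ug/mL to 200 ug/mL. That estimate corresponds to an expected step that the limit leaves unreadable from compound 2 to compound 4.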

Compound 4, half-maximal cytotoxic concentration: > 64 ug/mL
Compound 4: a limit, no number; the forecaster's own chance of this, stated with the estimate: 75%; the middle value lies beyond the limit too.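

Going by these compounds alone, compound 4 also stays at a limit in this assay, so no step linking it to compound 1, compound 2 or compound 3 can be read: the limit of > 64 ug/mL in this assay, at which 4 of the 4 values shown sit. The compounds shown leave open whether these four differ at all in tolerated concentration.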